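This account rests on a few compounds, and the source may have more. Where it says the series, first, only, none or still open, it means among the compounds named here.

Compound 1 `Cc1ccc(-c2nc(N)c3cc(Cl)ccc3n2)cc1`: 3.56 ug/mL
Compound 2 `Cc1ccc(-c2nc3ccc(Cl)cc3c(=S)o2)cc1`: 13.3 ug/mL
Compound 3 `Cc1ccc(C(=O)Nc2ccc(Cl)cc2C(=S)NN)cc1`: 4.98 ug/mL

All three numbers come from a functional assay on HeLa cells (Homo sapiens) for antiproliferative activity, read by MTT assay, with a stated time of 48 h; on this read-out higher numbers stand for weaker inhibition and lower numbers for stronger inhibition. Compound 1 gives the lowest of the three; compound 3 lies within the usual scatter of it, so the two cannot be ranked, while compound 2 stands beyond the scatter at a higher number. Compound 4 `C=CCSc1nc(-c2ccc(C)cc2)nc2ccc(Cl)cc12` differs from compound 1 in one place: allylsulfanyl in place of amino on an aromatic carbon. Among the compounds with values here, no measured pair shows a change of this kind, so nothing in the data fixes its size or direction. Only a modest shift in this assay is expected, with a slightly higher number judged somewhat more likely than a lower one. The expected step is a 1.4-fold higher number from compound 1 to compound 4 (0.15 log units; within the scatter). Compound 4 is therefore expected to give about 5 ug/mL, in a range from 2.2 ug/mL to 12 ug/mL.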

Compound 4, half-maximal inhibitory concentration: 9.66 ug/mL
The estimate for compound 4 lay 1.9-fold (0.29 log units) below the measured number; measured number inside the range.
By their numbers in this assay, from the lowest: compounds 1, 3, 4 and 2 (each within the scatter of the next, the first and the last beyond it).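

Replacing amino with allylsulfanyl on this aromatic carbon, next to the ring nitrogen, gives a 2.7-fold higher number from compound 1 to compound 4 (0.43 log units; beyond the scatter) in this assay. This position therefore responds to the group it carries, although the change is modest and compound 4 still gives a measured number. Nothing available explains the rise. The compounds shown leave open whether the sulfur, the longer chain or the missing hydrogen-bond donor matters most. A methylsulfanyl or allylamino group at this position would help to separate these features.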